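Swapping trifluoromethyl for methyl on two related cores

The source may hold more compounds than are shown below. What is called first, only, known or untested is meant among the compounds shown, and "the series" means these compounds.

Compound 1 `Cc1ccc(C(=O)Nc2nc(Cl)c3cn(C)nc3n2)cc1` and compound 2 `Cn1cc2c(Cl)nc(NC(=O)c3ccc(C(F)(F)F)cc3)nc2n1` share one core; compound 3 `CCOC(=O)c1nc(NC(=O)c2ccc(C(F)(F)F)cc2)nc2nn(CC(C)(C)C)cc12` and compound 4 `CCOC(=O)c1nc(NC(=O)c2ccc(C)cc2)nc2nn(CC(C)(C)C)cc12` share another, and the difference between the two cores is not broken down here. In an assay on CHO cells for displacement of a labelled ligand from adenosine receptor A3 (Homo sapiens), read by scintillation counting, with a stated time of 3 h (a lower number here means a stronger inhibitor, a higher number a weaker inhibitor), compound 2 gives 33500 nM, compound 1 gives 13500 nM, and compound 3 gives 1300 nM, the lowest of the three. Going from compound 2 to compound 1 the change is methyl in place of trifluoromethyl on an aromatic carbon, and it brought a 2.5-fold lower number from compound 2 to compound 1 (0.39 log units; beyond the scatter). Compound 4 carries the same change on the core of compound 3: methyl in place of trifluoromethyl on an aromatic carbon. Among the compounds with values here, since that single earlier step is the only guide, a similar modest lowering is expected, so compound 4 is estimated at 600 nM, within 250 nM to 1600 nM in this assay, meaning an expected step of a 2.2-fold lower number from compound 3 to compound 4 (0.34 log units; beyond the scatter).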

Compound 4, inhibition constant: 900 nM
Compound 4: middle estimate off by 1.5-fold (0.18 log units), on the low side, and the stated range covers the measured number.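

In this assay, methyl in place of trifluoromethyl on the core of compound 3 gives a 1.4-fold lower number from compound 3 to compound 4 (0.16 log units; within the scatter), so this step alone cannot be told apart from the noise of repeated measurement. Set beside the earlier step, it shows no sign that the core alters the effect of this change: the same change on two cores in this assay, a 2.5-fold lower number (0.39 log units; beyond the scatter) from compound 2 to compound 1 and a 1.4-fold lower number (0.16 log units; within the scatter) from compound 3 to compound 4, 1.7-fold (0.24 log units) apart, within the scatter of two such steps. Within the data shown here, this agreement rests on only two pairs of compounds, so it does not show that the step keeps the same size on every core.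

The compounds shown leave open what an amine or a methoxy group would do in the place of the methyl of compound 4. They also leave open what a carboxylic acid would do in place of the ethyl ester of compound 3.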